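Cyclopentyl in Place of Pyridinyl on the Alkyne of Compound 3

This account rests on a few compounds, and the source may have more. Where it says the series, first, only, none or still open, it means among the compounds named here.

Of the compounds shown here, three sharing one fused core have been measured in an assay on cells for inhibition of Indoleamine 2,3-dioxygenase 1 (Homo sapiens); a lower number here means a stronger inhibitor, a higher number a weaker inhibitor. The value of compound 1 `O=C(CSc1nnc2scc(C3CCCCC3)n12)c1ccc(Br)cc1` is a limit of the assay rather than a number. In this assay compound 1 gives > 10000 nM. Compound 2 `OC(c1ccccc1)c1cnc2scc(-c3ccc(Br)cc3)n12` gives 1090 nM in this assay. Compound 3 `N#Cc1ccc(NC(=O)NCc2cnc3scc(C#Cc4cccnc4)n23)cc1` gives 3200 nM in this assay. Of the two numbers shown, the number for compound 3 is the higher; compound 2 is its nearest neighbour, and the gap between compound 3 and compound 2 lies beyond the usual scatter.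

Compound 4 `N#Cc1ccc(NC(=O)NCc2cnc3scc(C#CC4CCCC4)n23)cc1` has not yet been measured. It differs from compound 3 by cyclopentyl in place of pyridin-3-yl on a triple-bonded carbon. Among the measured compounds shown here, no measured pair shows this same change, so the size of the step rests on expectation alone. A moderate weakening in this assay is expected, toward a higher number, with a real chance that compound 4 reaches only a limit. The step from compound 3 to compound 4 is expected to be a 1.7-fold higher number from compound 3 to compound 4 (0.24 log units; within the scatter). Compound 4 is therefore estimated at 5500 nM, within a range from 1800 nM to 16000 nM.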

Compound 4, half-maximal inhibitory concentration: 418 nM
For compound 4 the middle estimate is 13-fold (1.12 log units) above the measured one, and the stated range ends above it.
By their numbers in this assay, from the lowest: compound 4; then compound 2; then compound 3. At a limit, above all of these: compound 1.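

In this assay, among the compounds shown here, this is the first step between compounds that differ in one place, and it shows that the group on the triple-bonded carbon strongly affects the read-out: cyclopentyl in place of pyridin-3-yl gives a 7.7-fold lower number from compound 3 to compound 4 (0.88 log units; beyond the scatter), a step beyond the scatter. A six-membered aromatic ring with a hetero atom is therefore not needed at this position, since a five-membered non-aromatic ring of carbon only gives the lower number while the rest of the structure stays the same. Nothing among the data shown accounts for the size or the direction of this step.

This one change removes the ring nitrogen, the aromatic character and one ring atom all at once, so the compounds shown cannot say which of these differences matters, or whether they matter only in combination. A plain phenyl or a cyclohexyl on the same triple-bonded carbon would begin to separate them, while an open chain such as butyl or a ring carrying an amine would show how far the trend reaches beyond the single cyclopentyl.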